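The source may hold more compounds than are shown below. What is called first, only, known or untested is meant among the compounds shown, and "the series" means these compounds.

Compound 1, `COc1ccc(C2=NN(C3=NC(=O)/C(=C4\C(=O)Nc5ccc(Cl)cc54)S3)C(c3ccc(OC)cc3)C2)cc1`, gives 220 nM in a functional assay on cells (Cancer cell lines, Homo sapiens) for cytotoxicity, read by sulforhodamine B assay, with a stated time of 48 h; on this read-out higher numbers stand for weaker inhibition of growth and lower numbers for stronger inhibition of growth.
Compound 2, `COc1ccc(C2=NN(C3=NC(=O)/C(=C4\C(=O)Nc5ccc(Br)cc54)S3)C(c3ccc(Cl)cc3)C2)cc1`, gives 140 nM in this assay.

Of these two numbers, compound 2 has the lower one, but compound 1 lies within the usual scatter of it, so the two cannot be told apart. Compound 3, `COc1ccc(C2=NN(C3=NC(=O)/C(=C4\C(=O)Nc5ccc(Cl)cc54)S3)C(c3ccc(Cl)cc3)C2)cc1`, is yet to be measured in this assay. It differs from compound 2 in one place: chloro in place of bromo on an aromatic carbon. Among the compounds with values here, no pair of measured compounds differs by this change alone, so there is no direct precedent for the step. Compound 1 also carries chloro on the fused ring and gives a number close to that of compound 2, though it differs from compound 2 elsewhere as well. The step in this assay is therefore expected to be small, with no clear direction and within the scatter. Compound 3 is estimated at 170 nM, with a range from 70 nM to 420 nM. That would mean an expected step of a 1.2-fold higher number from compound 2 to compound 3 (0.08 log units; within the scatter).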

Compound 3, concentration for 50% growth inhibition: 200 nM
Compound 3: middle estimate off by 1.2-fold (0.07 log units), on the low side; the measured number falls inside the stated range.
By their numbers in this assay, from the lowest: compounds 2, 3 and 1 (each within the scatter of the next).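

In this assay, chloro in place of bromo on the six-membered aromatic ring of the fused system brings a step of a 1.4-fold higher number from compound 2 to compound 3 (0.15 log units; within the scatter) and so stays within the scatter; at this position, the two groups cannot be told apart. The same holds on a different aromatic carbon, where chloro in place of methoxy brings a step of a 1.1-fold lower number from compound 1 to compound 3 (0.04 log units; within the scatter) and also stays within the scatter. Nothing here offers an explanation for either result.

The compounds shown cover only bromo and chloro at the first place and only methoxy and chloro at the second. On these data alone, it remains open whether a quite different group at either place, such as an amine or a carboxylic acid, would shift the number beyond the scatter.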